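Dithiolethione for thioamide on a pentyl-ether linked core

The source may report more compounds than this note shows. Statements on the series, on what has been measured and on what is new or still open speak of the compounds shown alone.

In a functional assay on MCF7 cells (Homo sapiens) for antiproliferative activity, read by MTT assay, with a stated time of 48 h (on this read-out lower numbers stand for stronger inhibition and higher numbers for weaker inhibition), compound 1 `COc1cc(CNC(=O)CCCC/C=C/C(C)C)ccc1OC(=O)CCC(=O)Oc1ccc(-c2cc(=S)ss2)cc1` gives 2120 nM. Compound 2 `COc1cc(CNC(=O)CCCC/C=C/C(C)C)ccc1OC(=O)CCC(=O)Oc1ccc(C(N)=S)cc1` reaches only the limit of this assay, > 50000 nM. Going by these compounds, the change from compound 2 to compound 1, (a group of 6 heavy atoms (3 carbon, 3 sulfur; one five-membered aromatic ring with 2 hetero atoms) in place of a group of 3 heavy atoms (1 carbon, 1 nitrogen, 1 sulfur; no ring), on an aromatic carbon), brings an at least 23-fold lower number from compound 2 to compound 1 (1.37 log units; beyond the scatter), and the true size of that step stays open because compound 2 sits at the limit of > 50000 nM in this assay, at which 1 of the 3 values shown sits. Compound 3 `COc1cc(CNC(=O)CCCCCCC(C)C)ccc1OCCCCCOc1ccc(C(N)=S)cc1` gives 49300 nM in this assay. The difference between the cores of compound 3 and compound 2 is not broken down here. Compound 4 `COc1cc(CNC(=O)CCCCCCC(C)C)ccc1OCCCCCOc1ccc(-c2cc(=S)ss2)cc1` carries the same change on the core of compound 3, (a group of 6 heavy atoms (3 carbon, 3 sulfur; one five-membered aromatic ring with 2 hetero atoms) in place of a group of 3 heavy atoms (1 carbon, 1 nitrogen, 1 sulfur; no ring), on an aromatic carbon), at the same place. The step from compound 3 to compound 4 is expected to be a 20-fold lower number from compound 3 to compound 4 (1.29 log units; beyond the scatter), set beside the earlier step of an at least 23-fold lower number from compound 2 to compound 1 (1.37 log units; beyond the scatter), whose floor the limit of > 50000 nM in this assay, at which 1 of the 3 values shown sits, leaves unknown. Compound 4 is estimated at 2500 nM in this assay, within 800 nM to 8000 nM.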

Compound 4, half-maximal inhibitory concentration: 48700 nM
For compound 4 the middle estimate is 19-fold (1.29 log units) below the measured one, outside the stated range (above it).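

In this assay, putting the dithiolethione in place of the thioamide on the core of compound 3 gives a 1.0-fold lower number from compound 3 to compound 4 (0.01 log units; within the scatter), so the large step seen on the core of compound 1 does not carry over to this core: the same change on two cores in this assay, an at least 23-fold lower number (1.37 log units; beyond the scatter) from compound 2 to compound 1 and a 1.0-fold lower number (0.01 log units; within the scatter) from compound 3 to compound 4, at least 23-fold (1.36 log units) apart, beyond the scatter of two such steps

Compound 2 stands at a limit of the assay, so the earlier step is a bound and not a measured size: the limit of > 50000 nM in this assay, at which 1 of the 4 values shown sits.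

The result shows that the step depends on the core, but not which difference between the two cores decides it.

Going by these compounds, it stays open whether the step would return on a core that differs from compound 3 only in the linker or only in the acyl chain. Also open, on these data alone, is how a nitrile or a carboxylic acid would behave at the same place on either core.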